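The source may report more compounds than this note shows. Statements on the series, on what has been measured and on what is new or still open speak of the compounds shown alone.

Compound 3 `Cc1nc2c([nH]1)C(=O)/C(=N/c1cccc(Cl)c1)C(Cl)=C2O` gives 900 nM in an ADME assay (Rattus norvegicus) for inhibition (a higher number here means a weaker inhibitor, a lower number a stronger inhibitor), the lowest of the two single numbers available. Nearest to it is compound 2 `Cc1nc2c([nH]1)C(=O)/C(=N/c1ccc(I)cc1)C(Cl)=C2O`, which in this assay gives 1000 nM; the step of a 1.1-fold lower number from compound 2 to compound 3 (0.05 log units; within the scatter) lies within the scatter, so the two cannot be ranked. Compound 1 `Cc1nc2c([nH]1)C(=O)/C(=N/c1ccc(Cl)cc1)C(Cl)=C2O` has two entries in this assay, 2800 nM; 2820 nM (2 entries), which agree closely (the several entries of compound 1 in this assay, 2800 nM; 2820 nM (2 entries)).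

Compound 4 `Cc1nc2c([nH]1)C(=O)/C(=N/c1cccc(Cl)c1Cl)C(Cl)=C2O` has not yet been measured in this assay. It differs from compound 3 in one place: chloro in place of hydrogen on an aromatic carbon. For the measured compounds named here, no measured step adds a chloro group to a ring that already carries one; the single step that is known swapped 3-chlorophenyl for 4-iodophenyl and stayed within the scatter. There is thus no basis for expecting a change beyond the scatter, and compound 4 is expected to stay close to compound 3, with a 1.1-fold lower number from compound 3 to compound 4 (0.05 log units; within the scatter). Compound 4 is estimated at 800 nM, with a range from 300 nM to 2500 nM.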

Compound 4, half-maximal inhibitory concentration: 600 nM
Compound 4: middle estimate off by 1.3-fold (0.12 log units), on the high side, and the stated range covers the measured number.
By their numbers in this assay, from the lowest: compounds 4, 3 and 2 (each within the scatter of the next).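

Of the steps shown, this is the only one that adds a group to a ring already carrying one, and it gives a 1.5-fold lower number from compound 3 to compound 4 (0.18 log units; within the scatter) in this assay as its result. A second chloro group, ortho to the first on the six-membered aromatic ring, is therefore tolerated in this assay without a change that can be told from the scatter, something a swap between two substituted phenyl groups could not show. Nothing in the data shown bears on why the number stays so close.

Only chloro has been shown at this position, so whether a methoxy group, an amine or a carboxylic acid would shift the number beyond the scatter stays open. The same question holds for a longer chain such as propyl there.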